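Bromo to methyl on the aryl ketone of compound 3

The source may hold more compounds than are shown below. What is called first, only, known or untested is meant among the compounds shown, and "the series" means these compounds.

Three compounds were tested in a functional assay on MCF7 cells (Homo sapiens) for antiproliferative activity, read by sulforhodamine B assay, with a stated time of 72 h, tested at 10 uM; on this read-out higher numbers stand for a weaker effect at the one concentration tested and lower numbers for a stronger effect. Compound 1 `Cc1ccc(C(=O)CC2C(C#N)=C(N)Oc3ccc(Cl)cc32)cc1` gives 85.5%, compound 2 `COc1cc(Br)cc2c1OC(N)=C(C#N)C2CC(=O)c1ccc(C)cc1` gives 116%, and compound 3 `N#CC1=C(N)Oc2ccc(Br)cc2C1CC(=O)c1ccc(Br)cc1` gives 47.2%, the lowest of the three and beyond the scatter from both others. Compound 4 `Cc1ccc(C(=O)CC2C(C#N)=C(N)Oc3ccc(Br)cc32)cc1` has not yet been measured; it differs from compound 3 by methyl in place of bromo on an aromatic carbon. Compound 1 also carries a 4-methylphenyl and shows a markedly weaker effect than compound 3, so a step toward weaker activity is expected, beyond the scatter, from compound 3 to compound 4, of a number 32.8 percentage points higher from compound 3 to compound 4 (beyond the scatter). Compound 4 is therefore estimated at 80%, with a range from 55% to 105%.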

Compound 4, a percentage reported as activity, at one concentration (the size of the read-out at that concentration, not a potency): 69%
The estimate for compound 4 lay 11 percentage points above the measured number, and the stated range covers the measured number.
By their numbers in this assay, from the lowest: compound 3; then compound 4; then compound 1; then compound 2.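

In this assay, going by these compounds alone, the change from 4-bromophenyl to 4-methylphenyl gives the first single-place reading at this position, a number 21.8 percentage points higher from compound 3 to compound 4 (beyond the scatter), so bromo here gives the stronger effect of the pair. Within the data shown here, compound 4 also links the earlier compounds to this series, with bromo in place of chloro on the core giving a number 16.5 percentage points lower from compound 1 to compound 4 (beyond the scatter) and hydrogen in place of methoxy giving a number 47 percentage points lower from compound 2 to compound 4 (beyond the scatter).

Nothing measured here accounts for these steps. The compounds shown leave open how an amine, a carboxylic acid or a longer chain at this position would compare with bromo and methyl.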